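The compounds below may be only part of what the source reports. "The series", "measured", "known", "first", "only" and "open" are said of these compounds alone.

Measured compounds:
Compound 1 `Nc1ccn(C[C@H](O)[C@H]2OC(=O)C(OCc3ccccc3)=C2OCc2ccccc2)c(=O)n1` gives 44300 nM in a functional assay on HepG2 cells (Homo sapiens) for inhibition, read by MTT assay, with a stated time of 72 h; on this read-out higher numbers stand for weaker inhibition and lower numbers for stronger inhibition.
Compound 2 `O=C1O[C@H]([C@@H](O)Cn2ccc(NC(=O)c3ccccc3)nc2=O)C(OCc2ccccc2)=C1OCc1ccccc1` gives 62200 nM in this assay.
Compound 3 `O=C1O[C@H]([C@@H](O)Cn2c(=O)[nH]c(=O)[nH]c2=O)C(OCc2ccccc2)=C1OCc1ccccc1` returns only a limit of this assay, > 100000 nM.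

Compound 3 therefore stands at the limit of > 100000 nM in this assay, at which 1 of the 3 values shown sits, with no exact number known. Compound 4 `Nc1ncn(C[C@H](O)[C@H]2OC(=O)C(OCc3ccccc3)=C2OCc2ccccc2)c(=O)n1` differs from compound 3 by a group of 8 heavy atoms (3 carbon, 4 nitrogen, 1 oxygen; one six-membered aromatic ring with 3 hetero atoms) in place of a group of 9 heavy atoms (3 carbon, 3 nitrogen, 3 oxygen; one six-membered aromatic ring with 3 hetero atoms), on a saturated chain carbon, two bonds along the chain from an oxygen on a saturated carbon and a saturated ring carbon. Going by the values given here, the only measured step that bears on this change runs the other way: from compound 1 to compound 3 the change of ring gave an at least 2.2-fold higher number from compound 1 to compound 3 (0.35 log units; beyond the scatter). The step of a 1.4-fold higher number from compound 1 to compound 2 (0.15 log units; within the scatter) touches a different part of the molecule. Because compound 1 sits at 44300 nM, compound 4, whose ring is nearer that of compound 1, is expected to return an exact number again, with a step estimated at an at least 1.8-fold lower number from compound 3 to compound 4 (0.25 log units; that floor lies within the scatter). Compound 4 is estimated at 55000 nM, within 22000 nM to 130000 nM.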

Compound 4, half-maximal inhibitory concentration: > 100000 nM
Compound 4: only a limit was reported; the forecaster's own chance of this, stated with the estimate: 25%; at least 1.8-fold (0.25 log units) between middle value and limit.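

Compound 4 returns only a limit in this assay (> 100000 nM), so this second ring with 3 hetero atoms also gives no exact number at this saturated chain carbon. Against the ring of compound 1, the change leaves a gap beyond the scatter (an at least 2.2-fold higher number from compound 1 to compound 4 (0.35 log units; beyond the scatter)). Compound 4 thus joins compound 3 at the limit: the limit of > 100000 nM in this assay, at which 2 of the 4 values shown sit.

Both values are limits, so the step between compound 3 and compound 4 cannot be read. As far as these compounds go, whether an imidazole ring at this chain carbon would lower the number remains open.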